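Swapping phenyl for 4-acetamidocyclohexyl in a series at the limit

The source may report more compounds than this note shows. Statements on the series, on what has been measured and on what is new or still open speak of the compounds shown alone.

Compound 1 (`CC(C)(C)OC(=O)Nc1nc(-c2cc(F)ncc2Cl)cs1`) gives > 10000 nM in a functional assay on MV4-11 cells (Homo sapiens) for antiproliferative activity, read by CellTiter-Glo, with a stated time of 72 h (a lower number here means a stronger inhibitor of growth, a higher number a weaker inhibitor of growth), and this is a limit of the assay. Compound 2 (`Fc1cc(-c2csc(NCC3CCOCC3)n2)c(Cl)cn1`) gives > 10000 nM in this assay and this too is a limit. Compound 3 (`Clc1cnc(Nc2ccccc2)cc1-c1csc(NCC2CCOCC2)n1`) gives > 10000 nM in this assay and this is again a limit, so it has no number of its own. Among the measured compounds shown here, the three share the limit of > 10000 nM in this assay, at which 3 of the 3 values shown sit, as their only reading.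

Compound 4 (`CC(=O)N[C@H]1CC[C@H](Nc2cc(-c3csc(NCC4CCOCC4)n3)c(Cl)cn2)CC1`) carries 4-acetamidocyclohexyl in place of phenyl on a nitrogen on an aromatic ring. For the measured compounds named here, two measured steps bear on this change, namely a step that the two limits leave unreadable from compound 1 to compound 2 and a step that the two limits leave unreadable from compound 2 to compound 3 and neither offers a size to carry forward. The expectation therefore rests on the structural change alone, and it is uncertain. The estimate is an at least 16-fold lower number from compound 3 to compound 4 (1.22 log units; beyond the scatter) in the direction of stronger growth inhibition. Compound 4 is expected at 600 nM with an estimated range of 60 nM to 8000 nM in this assay and a reading at the limit remains possible.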

Compound 4, concentration for 50% growth inhibition: 3600 nM
Compound 4: the middle estimate sits 6.0-fold (0.78 log units) below what was measured; the range from low to high includes it.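

In this assay, 4-acetamidocyclohexyl in place of phenyl on a nitrogen on an aromatic ring gives an at least 2.7-fold lower number from compound 3 to compound 4 (0.44 log units; beyond the scatter), the only readable step shown; the earlier steps cannot be read. This shows that the group on this nitrogen can move growth inhibition in MV4-11 cells with the rest of the structure unchanged, which compound 1, compound 2 and compound 3 could not show. Compound 4 is the only compound shown with a measured number rather than a limit: the limit of > 10000 nM in this assay, at which 3 of the 4 values shown sit.

The change replaces the aromatic ring with a non-aromatic one, adds the acetamide and brings in defined stereocentres, all at once, so the compounds shown leave open which of these carries the step. Plain cyclohexyl, or 4-aminocyclohexyl with an amine in place of the acetamide, would begin to separate them.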